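Thioether versus amino substituent on the shared core

A few compounds are considered here, and "the series" means these few. Any claim that something is new, unique, unknown or untested is made for them only; others in the source may bear on it.

Measured so far in an in vitro functional assay on 1321-N1 cells for agonist activity at P2Y purinoceptor 2 (Homo sapiens), read by scintillation proximity assay and inositol phosphate accumulation; on this read-out lower numbers stand for an effect already at smaller amounts and higher numbers for an effect only at larger amounts of compound:
- compound 1 `CSc1nc(=O)ccn1[C@@H]1O[C@H](COP(=O)(O)OP(=O)(O)O)[C@@H](O)[C@H]1O` gives 523 nM
- compound 2 `CCCSc1nc(=O)ccn1[C@@H]1O[C@H](COP(=O)(O)OP(=O)(O)O)[C@@H](O)[C@H]1O` gives 1200 nM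
- compound 3 `CNc1nc(=O)ccn1[C@@H]1O[C@H](COP(=O)(O)OP(=O)(O)O)[C@@H](O)[C@H]1O` gives 7600 nM

Compound 3 stands at the highest number of the three: a 15-fold higher number from compound 1 to compound 3 (1.16 log units; beyond the scatter) and a 6.3-fold higher number from compound 2 to compound 3 (0.80 log units; beyond the scatter) both run beyond the scatter. Compound 4 `O=c1ccn([C@@H]2O[C@H](COP(=O)(O)OP(=O)(O)O)[C@@H](O)[C@H]2O)c(SCCc2ccccc2)n1` is not yet measured; it differs from compound 3 by phenethylsulfanyl in place of methylamino on an aromatic carbon. For the measured compounds named here, two measured steps bear on it. Exchanging the amino group for a thioether is covered by a 6.3-fold higher number from compound 2 to compound 3 (0.80 log units; beyond the scatter) read in reverse, a modest gain. Lengthening the chain on the sulfur is covered by a 2.3-fold higher number from compound 1 to compound 2 (0.36 log units; beyond the scatter), a modest loss, and phenethyl is larger still than propyl. These pulls partly cancel, so a modest decrease in this assay is expected, a 3.0-fold lower number from compound 3 to compound 4 (0.48 log units; beyond the scatter). Compound 4 is therefore estimated at 2500 nM, within 800 nM to 8000 nM.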

Compound 4, half-maximal effective concentration: 544 nM
The estimate for compound 4 lay 4.6-fold (0.66 log units) above the measured number; the measured number lies below the stated range.
By their numbers in this assay, from the lowest: compounds 1 and 4 (each within the scatter of the next); then compound 2; then compound 3.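

In this assay, growth of the chain on the sulfur brings no steady loss: phenyl in place of methyl on the chain gives a 2.2-fold lower number from compound 2 to compound 4 (0.34 log units; beyond the scatter), and benzyl in place of hydrogen gives a 1.0-fold higher number from compound 1 to compound 4 (0.02 log units; within the scatter). The thioether gain over methylamino can be large with this chain, at a 14-fold lower number from compound 3 to compound 4 (1.15 log units; beyond the scatter). Nothing available explains these steps.

Open, going by these compounds, is whether phenethylamino at this carbon would match phenethylsulfanyl, which would separate the linking atom from the chain. On these data alone, a longer chain such as phenylpropylsulfanyl also remains open.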